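Swapping an Alkenyl Ester Tail for a Chlorophenoxyethyl Chain

The source may report more compounds than this note shows. Statements on the series, on what has been measured and on what is new or still open speak of the compounds shown alone.

Of the compounds shown here, two sharing one core have been measured in a functional assay on HEK293 cells for antagonist activity at Voltage-dependent L-type calcium channel subunit alpha-1C (Oryctolagus cuniculus), read by FLIPR; a higher number here means a weaker inhibitor, a lower number a stronger inhibitor. Compound 1 `COCC1=C(C(=O)OC)C(c2cccc([N+](=O)[O-])c2)C(C(=O)OC)=C(C)N1` gives 115 nM. Compound 2 `C=C(C)CCOC(=O)C1=C(C)NC(C)=C(C(=O)OC)C1c1cccc([N+](=O)[O-])c1` gives 23 nM, the lower of the two numbers, and its gap to compound 1 lies beyond the scatter, so compound 2 is the stronger inhibitor of the pair. Compound 3 `COC(=O)C1=C(C)NC(C)=C(C(=O)OCCOc2ccccc2Cl)C1c1cccc([N+](=O)[O-])c1` is not yet measured and differs from compound 2 in one place: 2-chlorophenoxy in place of 1-methylethenyl on a saturated chain carbon, two bonds along the chain from an oxygen next to a carbonyl group. For the measured compounds named here, no measured step of this kind exists, so only a small step is expected, a 1.5-fold lower number from compound 2 to compound 3 (0.19 log units; within the scatter), perhaps toward a slightly stronger inhibitor. Compound 3 is therefore estimated at 15 nM, within 4 nM to 60 nM.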

Compound 3, half-maximal inhibitory concentration: 19 nM
Estimate against measurement, compound 3: 1.3-fold (0.10 log units) below, within the range that was stated.
By their numbers in this assay, from the lowest: compounds 3 and 2 (each within the scatter of the next); then compound 1.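

Putting 2-chlorophenoxy in place of 1-methylethenyl gives a 1.2-fold lower number from compound 2 to compound 3 (0.08 log units; within the scatter) in this assay and leaves the two compounds indistinguishable. This place on the ester chain therefore accepts a six-membered aromatic ring and a chlorine, 8 heavy atoms in place of 3, with no reading beyond the scatter. Nothing available explains why these two tails read alike.

As far as these compounds go, it remains open whether the chlorine itself matters, as a plain phenoxy group would show. Also open, from the compounds shown here alone, is how an amine or a carboxylic acid at this place on the chain would read.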